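This account rests on a few compounds, and the source may have more. Where it says the series, first, only, none or still open, it means among the compounds named here.

Measured compounds:
- compound 1, `C#CCOc1ccc2c(=O)c(-c3cc(OC)c(OC)cc3OC)coc2c1`, 4950 nM
- compound 2, `COc1cc(OC)c(-c2coc3cc(OCc4ccccc4)ccc3c2=O)cc1OC`, 1320 nM
- compound 3, `COc1cc(OC)c(-c2coc3cc(OCc4ccc(F)cc4)ccc3c2=O)cc1OC`, 1000 nM

In a functional assay on HepG2 cells (Homo sapiens) for antiproliferative activity, read by MTT assay, with a stated time of 24 h (a lower number here means a stronger inhibitor, a higher number a weaker inhibitor), compound 1 gives the highest number of the three, with compound 2 nearest and compound 3 furthest from it. Compound 4, `COc1cc(OC)c(-c2coc3cc(OCc4ccc(Br)cc4)ccc3c2=O)cc1OC`, has not yet been measured. Its difference from compound 1 is 4-bromophenyl in place of ethynyl on a saturated chain carbon bound to an oxygen on an aromatic ring. Among the measured compounds shown here, two measured steps bear on this change, a 3.8-fold lower number from compound 1 to compound 2 (0.57 log units; beyond the scatter) and a 5.0-fold lower number from compound 1 to compound 3 (0.69 log units; beyond the scatter), both modest and both beyond the scatter. A further step, a 1.3-fold lower number from compound 2 to compound 3 (0.12 log units; within the scatter), lies within the scatter. Compound 4 is therefore expected to give a lower number than compound 1, a step of about a 5.0-fold lower number from compound 1 to compound 4 (0.69 log units; beyond the scatter). The estimate for compound 4 in this assay is 1000 nM, with a range from 450 nM to 2200 nM.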

Compound 4, half-maximal inhibitory concentration: 1050 nM
For compound 4 the middle estimate is 1.1-fold (0.02 log units) below the measured one; low and high end bracket the measured number.
By their numbers in this assay, from the lowest: compounds 3, 4 and 2 (each within the scatter of the next); then compound 1.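

In this assay, the 4-bromophenyl group in place of ethynyl also lowers the number (a 4.7-fold lower number from compound 1 to compound 4 (0.67 log units; beyond the scatter)), so the change seen with phenyl and 4-fluorophenyl at this place extends to a third aryl group. The bromo substituent adds no readable difference, either in place of fluoro (a 1.1-fold higher number from compound 3 to compound 4 (0.02 log units; within the scatter)) or in place of hydrogen (a 1.3-fold lower number from compound 2 to compound 4 (0.10 log units; within the scatter)). No measurement offers an explanation for these results. The compounds shown leave open whether an amine or a carboxylic acid on the phenyl ring would give a similar number. They also leave open how a longer chain in place of propargyl or 4-bromobenzyl would read.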